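Bromine moved round the benzyl ring: what to expect

A few compounds are considered here, and "the series" means these few. Any claim that something is new, unique, unknown or untested is made for them only; others in the source may bear on it.

Compound 1 `CN(Cc1ccccc1)C(=O)c1cc2c(Cc3ccccc3)n[nH]c2cc1O` is the reference point of this small set. In a functional assay on A2780 cells (Homo sapiens) for antiproliferative activity, read by resazurin assay, with a stated time of 72 h (on this read-out higher numbers stand for weaker inhibition and lower numbers for stronger inhibition), compound 1 gives 980 nM. Compound 2 `CN(Cc1cccc(Br)c1)C(=O)c1cc2c(Cc3ccccc3)n[nH]c2cc1O` carries bromo in place of hydrogen on an aromatic carbon and in this assay compound 2 gives 7100 nM, which is a 7.2-fold higher number from compound 1 to compound 2 (0.86 log units; beyond the scatter). Compound 3 `Cc1cccc(Cc2n[nH]c3cc(O)c(C(=O)N(C)Cc4ccccc4)cc23)c1` differs from compound 1 by methyl in place of hydrogen on an aromatic carbon; in this assay compound 3 gives 490 nM, a move of a 2.0-fold lower number from compound 1 to compound 3 (0.30 log units; within the scatter). Compound 4 `Cc1cccc(Cc2n[nH]c3cc(O)c(C(=O)N(C)Cc4ccccc4Br)cc23)c1` has not yet been measured; it differs from compound 3 by bromo in place of hydrogen on an aromatic carbon. For the measured compounds named here, this is the same kind of change as the one from compound 1 to compound 2, but not the same: there the bromo sits meta to a large group, here it sits ortho to a large group. Going by the values given here, the only step of this kind measured so far is a 7.2-fold higher number from compound 1 to compound 2 (0.86 log units; beyond the scatter), and it raised the number. On that basis compound 4 is expected to show a step of a 5.7-fold higher number from compound 3 to compound 4 (0.76 log units; beyond the scatter), with a wide margin because the placement differs. Compound 4 is therefore estimated at 2800 nM, with a likely range from 900 nM to 9000 nM.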

Compound 4, half-maximal inhibitory concentration: 310 nM
The estimate for compound 4 lay 9.0-fold (0.96 log units) above the measured number, outside the stated range (below it).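

In this assay, bromo in place of hydrogen on an aromatic carbon of the benzyl group gives a 1.6-fold lower number from compound 3 to compound 4 (0.20 log units; within the scatter), so on this core the change does not reproduce the earlier rise, and the step cannot be carried over from one core to the other at a fixed size: the same change on two cores in this assay, a 7.2-fold higher number (0.86 log units; beyond the scatter) from compound 1 to compound 2 and a 1.6-fold lower number (0.20 log units; within the scatter) from compound 3 to compound 4, 11-fold (1.06 log units) apart, beyond the scatter of two such steps

This does not show which difference accounts for the gap, since the two pairs differ both in where the bromo sits and in the methyl that compound 3 and compound 4 carry. For the compounds shown here, each core also supplies only one pair, so neither step shows how bromo behaves in general on that core.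

The compounds shown leave open how the 2-bromobenzyl group behaves on the core of compound 1, a comparison that would separate the placement of the bromo from the effect of the methyl. They also leave open whether a chloro, a methoxy or an amine in that place would follow the bromo.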